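Fluoro in Place of Trifluoromethyl on the Shared Core

The source may hold more compounds than are shown below. What is called first, only, known or untested is meant among the compounds shown, and "the series" means these compounds.

In an assay on isolated protein for inhibition of serine/threonine-protein kinase PLK1 (Homo sapiens), read by radiometric assay and 33P incorporation, with a stated time of 40 min, tested at 20 uM, in the presence of a further agent that is not named here (a lower number here means less inhibition, a higher number more inhibition at the concentration tested (going by the name of the read-out)), compound 2 `CCNc1cc(-c2ccc(NC(=O)Nc3ccc(OC)cc3)cc2C(F)(F)F)ccn1` gives 62.1%, the second highest of the three numbers shown. Nearest to it is compound 3 `CCNc1cc(-c2ccc(NC(=O)Nc3ccccc3Cl)cc2C(F)(F)F)ccn1`, which in this assay gives 71.6%; furthest is compound 1 `CCNc1cc(-c2ccc(NC(=O)Nc3ccc(C)cc3)cc2C(F)(F)F)ccn1`, which in this assay gives 42.6%. The step of a number 9.5 percentage points higher from compound 2 to compound 3 (within the scatter) lies within the scatter, whereas a number 19.5 percentage points higher from compound 1 to compound 2 (beyond the scatter) and a number 29 percentage points higher from compound 1 to compound 3 (beyond the scatter) lie beyond it. Compound 4 `CCNc1cc(-c2ccc(NC(=O)Nc3ccc(OC)cc3)cc2F)ccn1` differs from compound 2 by fluoro in place of trifluoromethyl on an aromatic carbon. Within the data shown here, all three measured steps alter the aryl group on the amide-type nitrogen and leave the trifluoromethyl untouched, so none of them bears directly on this change; the data hold no example of replacing the trifluoromethyl anywhere. Without a comparable step, the expected change is none beyond the scatter, though with wide uncertainty, so the estimated step is a number 7.1 percentage points lower from compound 2 to compound 4 (within the scatter). For compound 4 in this assay the estimate is 55%, with a range from 30% to 80%.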

Compound 4, a percentage reported as inhibition, at one concentration (the size of the read-out at that concentration, not a potency): 47.1%
For compound 4 the middle estimate is 7.9 percentage points above the measured one; the measured number falls inside the stated range.
By their numbers in this assay, from the lowest: compounds 1 and 4 (each within the scatter of the next); then compounds 2 and 3 (each within the scatter of the next).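

Among these compounds, until now the trifluoromethyl had stayed constant, and this is the first change at this position, ortho to the 2-(ethylamino)pyridin-4-yl group. In this assay, fluoro in place of trifluoromethyl gives a number 15 percentage points lower from compound 2 to compound 4 (beyond the scatter), so the position is not indifferent to the group it carries, even though neither group counts a hydrogen-bond donor or acceptor. Nothing in the available data accounts for this drop.

Among the compounds shown here, the change is seen only with the 4-methoxyphenyl group on the amide-type nitrogen, so whether it carries over to the 2-chlorophenyl or 4-methylphenyl compounds remains open. Also open, going by these compounds, is how a nitrile, a methyl or a plain hydrogen at this position would read in this assay, and whether the response follows the size of the group there.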